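A Methyl on the Piperidine Ring of Compound 2

The source may hold more compounds than are shown below. What is called first, only, known or untested is meant among the compounds shown, and "the series" means these compounds.

Compound 1, `COc1cc2c(Oc3ccc(NC(=O)c4cn(-c5ccc(Br)cc5)nn4)cc3F)ccnc2cc1OCCCN1CCCCC1`, gives 150 nM in a functional assay on MKN-45 cells (Homo sapiens) for cytotoxicity, read by MTT assay, with a stated time of 72 h; a lower number here means a stronger inhibitor, a higher number a weaker inhibitor.
Compound 2, `COc1cc2c(Oc3ccc(NC(=O)c4cn(-c5c(C)cccc5C)nn4)cc3F)ccnc2cc1OCCCN1CCCCC1`, gives 2140 nM in this assay.

Compound 2 stands highest of the two numbers; its nearest neighbour is compound 1, separated by a 14-fold higher number from compound 1 to compound 2 (1.15 log units; beyond the scatter). Compound 3, `COc1cc2c(Oc3ccc(NC(=O)c4cn(-c5c(C)cccc5C)nn4)cc3F)ccnc2cc1OCCCN1CCC(C)CC1`, differs from compound 2 by methyl in place of hydrogen on a saturated ring carbon. Going by the values given here, no measured step touches this ring: the only step known, a 14-fold higher number from compound 1 to compound 2 (1.15 log units; beyond the scatter), concerns the group on the aromatic nitrogen and does not bear on it. The expected step is a 1.0-fold lower number from compound 2 to compound 3 (0.01 log units; within the scatter), none beyond the scatter. Compound 3 is therefore estimated at 2100 nM, with a range from 700 nM to 6500 nM.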

Compound 3, half-maximal inhibitory concentration: 4310 nM
For compound 3 the middle estimate is 2.1-fold (0.31 log units) below the measured one; the measured number falls inside the stated range.
By their numbers in this assay, from the lowest: compound 1; then compounds 2 and 3 (each within the scatter of the next).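

In this assay the change from piperidin-1-yl to 4-methylpiperidin-1-yl gives a 2.0-fold higher number from compound 2 to compound 3 (0.30 log units; within the scatter) and is the first step shown on this ring. A methyl three ring bonds from the ring nitrogen thus does not separate the two compounds beyond the scatter, unlike the earlier change on the aromatic nitrogen. No evidence is available that bears on this result.

The compounds shown leave open how a morpholine ring or a 4-hydroxypiperidin-1-yl group would read in this assay. They also leave open whether the same methyl would give a similar step with the 4-bromophenyl group of compound 1.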